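Compound 3: a 3-methoxyphenyl swap on the series

The compounds below may be only part of what the source reports. "The series", "measured", "known", "first", "only" and "open" are said of these compounds alone.

Values so far in a physicochemical assay for solubility, read by HPLC, using the shake flask method (on this read-out lower numbers stand for lower solubility and higher numbers for higher solubility), for two compounds
- compound 1 `COC(=O)c1cccc(-c2cnc3[nH]cc(-c4ccccc4)c3c2)c1` gives 2500 nM
- compound 2 `COC(=O)c1cccc(-c2cnc3[nH]cc(-c4cccnc4)c3c2)c1` gives 1900 nM

Among the measured compounds shown here, compound 2 stands within the scatter of compound 1, the only other number. The next entry is compound 3 `COC(=O)c1cccc(-c2cnc3[nH]cc(-c4cccc(OC)c4)c3c2)c1` with 3-methoxyphenyl in place of pyridin-3-yl on an aromatic carbon. For the measured compounds named here, one measured step bears on this, an exchange at the same aromatic carbon, with a 1.3-fold lower number from compound 1 to compound 2 (0.12 log units; within the scatter) in this assay as its size. It offers no ground for expecting a step beyond the scatter, in either direction. The estimated step is a 1.1-fold lower number from compound 2 to compound 3 (0.02 log units; within the scatter) and so nothing beyond the scatter. For compound 3 the estimate is 1800 nM with an expected range from 700 nM to 4000 nM on this read-out.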

Compound 3, solubility: 1000 nM
The estimate for compound 3 lay 1.8-fold (0.26 log units) above the measured number; low and high end bracket the measured number.
By their numbers in this assay, from the lowest: compounds 3, 2 and 1 (each within the scatter of the next, the first and the last beyond it).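

Among the compounds shown here, with methoxy in place of hydrogen on an aromatic carbon, this assay gives a 2.5-fold lower number from compound 1 to compound 3 (0.40 log units; beyond the scatter), the first step beyond the scatter, though a modest one. The exchange of pyridin-3-yl for 3-methoxyphenyl at the same place gives a 1.9-fold lower number from compound 2 to compound 3 (0.28 log units; within the scatter), so this pair stays unseparated. Nothing available explains either step.

Open, from the compounds shown here alone, is how an amine or a carboxylic acid in place of the methoxy would read at this position. Also open, going by these compounds, is whether a longer chain would extend the step seen with 3-methoxyphenyl.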